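Anilino variation on a shared nitrile core

This account rests on a few compounds, and the source may have more. Where it says the series, first, only, none or still open, it means among the compounds named here.

Measured so far in a functional assay on B16-F10 cells (Mus musculus) for inhibition, read by MTT assay, with a stated time of 72 h; on this read-out lower numbers stand for stronger inhibition and higher numbers for weaker inhibition: compound 1 `COc1ccc(Nc2nc(SCc3cn(Cc4ccccc4Cl)nn3)nc(-c3ccccc3)c2C#N)cc1` gives 3990 nM; compound 2 `N#Cc1c(Nc2ccc(Cl)cc2)nc(SCc2cn(Cc3ccccc3Cl)nn2)nc1-c1ccccc1` gives 1590 nM; compound 3 `COc1ccccc1Nc1nc(SCc2cn(Cc3ccccc3Cl)nn2)nc(-c2ccccc2)c1C#N` gives 7860 nM.

In this assay compound 3 stands at the highest number of the three. The step of a 2.0-fold higher number from compound 1 to compound 3 (0.29 log units; within the scatter) lies within the scatter, whereas the step of a 4.9-fold higher number from compound 2 to compound 3 (0.69 log units; beyond the scatter) lies beyond it. Compound 4 `Cc1cccc(Nc2nc(SCc3cn(Cc4ccccc4Cl)nn3)nc(-c3ccccc3)c2C#N)c1` differs from compound 3 by 3-methylphenyl in place of 2-methoxyphenyl on a nitrogen on an aromatic ring. Going by the values given here, neither measured step is this exact change, but both alter the aryl on the same nitrogen, and the one step beyond the scatter shows that leaving 2-methoxyphenyl can lower the number. Among the compounds with values here, a modest lowering is therefore expected, a 2.2-fold lower number from compound 3 to compound 4 (0.35 log units; beyond the scatter), with broad uncertainty since no 3-methylphenyl analogue exists. Compound 4 is estimated at 3500 nM, range 1200 nM to 9000 nM.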

Compound 4, half-maximal inhibitory concentration: 13500 nM
The estimate for compound 4 lay 3.9-fold (0.59 log units) below the measured number; measured number outside the range, above it.
By their numbers in this assay, from the lowest: compound 2; then compounds 1, 3 and 4 (each within the scatter of the next, the first and the last beyond it).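

Changing 2-methoxyphenyl to 3-methylphenyl on this nitrogen gives no separation (a 1.7-fold higher number from compound 3 to compound 4 (0.23 log units; within the scatter)), so these two aryl groups cannot be told apart here. The 3-methylphenyl group does stand apart from both 4-chlorophenyl (an 8.5-fold higher number from compound 2 to compound 4 (0.93 log units; beyond the scatter)) and 4-methoxyphenyl (a 3.4-fold higher number from compound 1 to compound 4 (0.53 log units; beyond the scatter)), which widens the spread seen across this position. Nothing available explains these gaps.

Going by these compounds, what 4-methylphenyl or 3-chlorophenyl would give on this nitrogen remains open. So does whether the gaps follow the group itself or its place on the aryl ring.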